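Swapping an Isopropyl Amide for an Amino Acid Tail

A few compounds are considered here, and "the series" means these few. Any claim that something is new, unique, unknown or untested is made for them only; others in the source may bear on it.

Compound 1, `CC(C)NC(=O)c1ccc(NCc2cncn2Cc2ccc(C#N)cc2)cc1-c1ccccc1`, gives only the assay limit > 10 uM in a functional assay on NIH3T3 cells (Mus musculus); on this read-out lower numbers stand for an effect already at smaller amounts and higher numbers for an effect only at larger amounts of compound.
Compound 2, `COC(=O)[C@H](CCSC)NC(=O)c1ccc(NCc2cncn2Cc2cccc(C#N)c2)cc1-c1ccccc1`, gives only the limit > 10 uM in this assay.
Compound 3, `CSCC[C@H](NC(=O)c1ccc(CNCc2c[nH]cn2)cc1-c1ccccc1C)C(=O)O`, gives only the limit > 25 uM in this assay.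

None of these values is a number; each is a limit. Compound 1 stands at the limit of > 10 uM in this assay, at which 2 of the 3 values shown sit, and compound 3 at the limit of > 25 uM in this assay, at which 1 of the 3 values shown sits. Compound 4, `CSCC[C@H](NC(=O)c1ccc(NCc2cncn2Cc2ccc(C#N)cc2)cc1-c1ccccc1)C(=O)O`, has not yet been measured; it differs from compound 1 by 1-carboxy-3-(methylsulfanyl)propyl in place of isopropyl on an amide-type nitrogen. Among the measured compounds shown here, no measured pair differs in only one place, so no step size can be read from the numbers. Because compound 1 sits at the limit of > 10 uM in this assay, at which 2 of the 3 values shown sit, and compound 3 at the limit of > 25 uM in this assay, at which 1 of the 3 values shown sits, the step from compound 1 to compound 4 is expected to be a step that the limit leaves unreadable from compound 1 to compound 4, without a direction beyond the usual scatter. Compound 4 is therefore estimated at 15 uM, between 5 uM and 60 uM, and another limit rather than a number would be expected as the likelier outcome.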

Compound 4, concentration for half-maximal effect: > 10 uM
Compound 4: a limit, no number (the forecaster's own chance of this, stated with the estimate: 70%); the middle value is on the limit's open side.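

Compound 1 and compound 4 each give only a limit, not a number, and the step between them cannot be read. The compounds shown leave open whether 1-carboxy-3-(methylsulfanyl)propyl in place of isopropyl shifts the effect in this assay at all.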